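Swapping the hydroxyphenyl hydrazone for a chlorophenyl hydrazone

The compounds below may be only part of what the source reports. "The series", "measured", "known", "first", "only" and "open" are said of these compounds alone.

Compound 1, `CC1=CC[C@@H]([C@@](C)(O)CCCC(C)(C)NC=S)CC1`: in a functional assay on NCI/ADR cells (Homo sapiens) for cytotoxicity, read by sulforhodamine B assay (a higher number here means a weaker inhibitor of growth, a lower number a stronger inhibitor of growth), compound 1 gives > 100000 nM, a limit of the assay.
Compound 2, `CC1=CC[C@@H]([C@@](C)(O)CCCC(C)(C)NC(=S)N/N=C\c2ccc(O)cc2)CC1`: in this assay compound 2 gives 6070 nM.
Compound 3, `CC1=CC[C@@H]([C@@](C)(O)CCCC(C)(C)NC(=S)N/N=C\c2ccc([N+](=O)[O-])cc2)CC1`: in this assay compound 3 gives > 100000 nM, a limit of the assay.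

Compound 2 is thus the only one of the three with a number; the other two sit at the limit of > 100000 nM in this assay, at which 2 of the 3 values shown sit. Compound 4, `CC1=CC[C@@H]([C@@](C)(O)CCCC(C)(C)NC(=S)N/N=C\c2ccccc2Cl)CC1`, differs from compound 2 by 2-chlorophenyl in place of 4-hydroxyphenyl on a carbon with a double bond to nitrogen. For the measured compounds named here, the one measured step at that position, an at least 16-fold higher number from compound 2 to compound 3 (1.21 log units; beyond the scatter), was large and pushed the value out to the limit. A weaker inhibition of growth than compound 2 is therefore expected for compound 4, with a real chance that only a limit is reported. Compound 4 is estimated at 30000 nM, between 8000 nM and 100000 nM. This expected change amounts to a 4.9-fold higher number from compound 2 to compound 4 (0.69 log units; beyond the scatter).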

Compound 4, concentration for total growth inhibition: > 100000 nM
Compound 4: no number, only a limit; the forecaster's own chance of this, stated with the estimate: 35%; middle value at least 3.3-fold (0.52 log units) from the limit.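

Replacing 4-hydroxyphenyl with 2-chlorophenyl gives an at least 16-fold higher number from compound 2 to compound 4 (1.21 log units; beyond the scatter), so a second, quite different group on this carbon also loses the measurable growth inhibition of compound 2. The step from compound 3 to compound 4 cannot be read, since both values are limits. Only compound 2 keeps a number, and the rest gather at one limit: the limit of > 100000 nM in this assay, at which 3 of the 4 values shown sit.

Going by these compounds, compound 4 changes both the substituent and its place on the ring at once, so it remains open which of the two matters. A 4-methoxyphenyl or 4-aminophenyl group on this carbon would separate them.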